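Compound 3 to compound 4: chloro in place of amino

This account rests on a few compounds, and the source may have more. Where it says the series, first, only, none or still open, it means among the compounds named here.

In an ADME assay on CCRF-CEM cells (Homo sapiens) for cytotoxicity, with a stated time of 5 days (on this read-out higher numbers stand for weaker inhibition and lower numbers for stronger inhibition), compound 3 (`CN(C)c1nc(N)nc2c1ncn2[C@H]1C[C@H](N=[N+]=[N-])[C@@H](CO)O1`) gives > 100000 nM as a limit and not a number. Compound 1 (`C=CCNc1nc(N)nc2c1ncn2[C@H]1C[C@H](N=[N+]=[N-])[C@@H](CO)O1`) gives > 100000 nM as a limit too. Compound 2 (`[N-]=[N+]=N[C@H]1C[C@H](n2cnc3c(NCCCCCO)nc(N)nc32)O[C@@H]1CO`) gives > 100000 nM as a limit too. For the measured compounds named here, the series so far therefore stands at the limit of > 100000 nM in this assay, at which 3 of the 3 values shown sit, and offers no measured number to reason from.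

Compound 4 (`CN(C)c1nc(Cl)nc2c1ncn2[C@H]1C[C@H](N=[N+]=[N-])[C@@H](CO)O1`) keeps the dimethylamino group of compound 3. The change is chloro in place of amino on an aromatic carbon and is chloro in place of amino on an aromatic carbon between two ring nitrogen atoms, meta to a dimethylamino group.

The measured steps are a step that the two limits leave unreadable from compound 1 to compound 2 and a step that the two limits leave unreadable from compound 1 to compound 3 and a step that the two limits leave unreadable from compound 2 to compound 3 in this assay and all of them concern the other substituent. In each, the amino group that leaves here stays in place, so none of them tests this change, and none has a readable size. Going by the values given here, with no measured step to carry over, no direction is expected and no shift beyond the scatter is predicted. The estimated step is a number no higher from compound 3 to compound 4 (the limit leaves the size open) with a report at the same limit as the likeliest outcome. For compound 4 the expected value is 100000 nM with an estimated range of 30000 nM to 200000 nM in this series.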

Compound 4, half-maximal inhibitory concentration: > 100000 nM
Compound 4 gave a limit, no number; the forecaster's own chance of this, stated with the estimate: 70%; the middle value sits exactly at the limit.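

Compound 3 and compound 4 both stand as limits and not numbers in this assay, so no step can be read between them: the limit of > 100000 nM in this assay, at which 4 of the 4 values shown sit.

The compounds shown leave open whether chloro in place of amino on this aromatic carbon shifts the half-maximal inhibitory concentration at all, and in which direction.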